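A Ring Contraction Tested Against a Cytotoxicity Ceiling

The source may hold more compounds than are shown below. What is called first, only, known or untested is meant among the compounds shown, and "the series" means these compounds.

Compound 1 `Cc1c(C)c2c(c(C)c1O)CCC(C)(C(=O)NC1CC(C)(C)N([O])C(C)(C)C1)O2` is the reference point of this small set. In a toxicity assay on cells (Cricetulus griseus) for cytotoxicity, read by MTT assay, with a stated time of 72 h (a higher number here means a weaker inhibitor, a lower number a stronger inhibitor), compound 1 gives 186000 nM. Compound 2 `Cc1c(C)c2c(c(C)c1OC(=O)CCC(=O)O)CCC(C)(C(=O)NC1CC(C)(C)N([O])C(C)(C)C1)O2` carries a (2-carboxyethyl)carbonyl in place of hydrogen on an oxygen on an aromatic ring. In this assay compound 2 reaches only the limit of the assay, > 300000 nM. Compound 3 `CC1(C)CC(CNC(=O)CCC(=O)O)C(C)(C)N1[O]`, a much smaller structure, likewise reaches a limit in this assay, > 300000 nM. Within the data shown here, the single measured step, an at least 1.6-fold higher number from compound 1 to compound 2 (0.20 log units; that floor lies within the scatter), has a floor within the scatter, so compound 2 stands at or beyond the ceiling of this assay, sharing (the limit of > 300000 nM in this assay, at which 2 of the 3 values shown sit).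

Compound 4 `Cc1c(C)c2c(c(C)c1OC(=O)CCC(=O)O)CCC(C)(C(=O)NCC1CC(C)(C)N([O])C1(C)C)O2` differs from compound 2 by a group of 11 heavy atoms (9 carbon, 1 nitrogen, 1 oxygen; one five-membered non-aromatic ring with 1 hetero atom) in place of a group of 11 heavy atoms (9 carbon, 1 nitrogen, 1 oxygen; one six-membered non-aromatic ring with 1 hetero atom), on an amide-type nitrogen. Among the measured compounds shown here, no measured step touches this part of the molecule; the one step available concerns the aromatic oxygen instead. One therefore expects no step beyond the scatter in this assay, and the estimate is written as a step that the limit leaves unreadable from compound 2 to compound 4. Compound 4 is expected to give 400000 nM, in a range from 150000 nM to 1500000 nM, and most likely the assay will again report a limit rather than a number.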

Compound 4, half-maximal inhibitory concentration: > 300000 nM
Compound 4 was reported as a limit (the forecaster's own chance of this, stated with the estimate: 75%); the middle value lies beyond the limit too.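

In this assay compound 4 gives > 300000 nM, which is a limit and not a number. Among these compounds, compound 2 also stands at a limit, so no step between compound 2 and compound 4 can be read. The compounds shown leave open whether the five-membered ring in place of the six-membered ring changes cytotoxicity at all.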